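The source may hold more compounds than are shown below. What is called first, only, known or untested is meant among the compounds shown, and "the series" means these compounds.

Measured compounds:

Compound 1, `Oc1ccc(-c2cc(-c3cccc(Cl)c3)nc(-c3ccccn3)c2)cc1`: in a functional assay on DU-145 cells (Homo sapiens) for cytotoxicity, read by CCK-8 assay and cell counting, with a stated time of 2 days (a lower number here means a stronger inhibitor, a higher number a weaker inhibitor), compound 1 gives 35200 nM.
Compound 2, `Oc1ccc(-c2cc(-c3ccsc3)nc(-c3cccc(Cl)c3)c2)cc1`: in this assay compound 2 gives 6220 nM.

Compound 2 holds the lower of the two numbers seen so far. Going by the values given here, the only measured step, a 5.7-fold lower number from compound 1 to compound 2 (0.75 log units; beyond the scatter), shows that swapping one small aromatic ring for another on the shared core can shift the read-out by a clear margin, beyond the usual scatter.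

Compound 3, `Oc1ccc(-c2cc(-c3cccc(Cl)c3)nc(-c3ccco3)c2)cc1`, is the next member of the series. It differs from compound 2 in one place: furan-2-yl in place of thiophen-3-yl on an aromatic carbon. Among the compounds with values here, no measured step describes this particular exchange of one five-membered ring for another, so the step from compound 1 to compound 2 serves only as a rough guide to how much such a ring swap can matter, not to its direction. Both rings carry one hetero atom and are of similar size, so the expected change is modest. The estimate for compound 3 is 9000 nM, within a range of 3000 nM to 30000 nM, a step of a 1.4-fold higher number from compound 2 to compound 3 (0.16 log units; within the scatter) that is expected to stay near the scatter.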

Compound 3, half-maximal inhibitory concentration: 5750 nM
Compound 3: middle estimate off by 1.6-fold (0.19 log units), on the high side; the measured number falls inside the stated range.
By their numbers in this assay, from the lowest: compounds 3 and 2 (each within the scatter of the next); then compound 1.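

In this assay, furan-2-yl in place of thiophen-3-yl, on the aromatic carbon next to the ring nitrogen, gives a 1.1-fold lower number from compound 2 to compound 3 (0.03 log units; within the scatter) and so leaves the two numbers indistinguishable, although the ring's hetero atom changes from sulfur to oxygen and the two ring names show different attachment points. Furan-2-yl in place of pyridin-2-yl gives a 6.1-fold lower number from compound 1 to compound 3 (0.79 log units; beyond the scatter), so a second five-membered ring also separates clearly from compound 1, and among these three compounds the clear divide lies between pyridin-2-yl and the two five-membered rings, with no compound going against it. No supporting information is available to explain this divide.

The compounds shown leave open whether it is the six-membered ring itself or something specific to pyridin-2-yl that sets compound 1 apart, a question that a plain phenyl group at this position could help to answer. They also leave open how this position would respond to a five-membered ring carrying a substituent, such as an aminomethyl group or a carboxylic acid.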